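The compounds below may be only part of what the source reports. "The series", "measured", "known", "first", "only" and "open" are said of these compounds alone.

Three close relatives of one core were tested in an assay for inhibition of zeta-carotene desaturase, chloroplastic/chromoplastic (Capsicum annuum), using a Dixon plot, with a stated time of 8 h; on this read-out higher numbers stand for weaker inhibition and lower numbers for stronger inhibition. Compound 1 `CCC(COc1ccccc1)OC(=O)NCc1ccccc1` is the parent; in this assay compound 1 gives only a limit of the assay, > 100000 nM. Compound 2 `CCC(COc1ccc(Cl)cc1)OC(=O)NCc1ccccc1` carries a chloro in place of hydrogen on an aromatic carbon, and in this assay compound 2 likewise gives only a limit, > 100000 nM. Compound 3 `CCC(COc1cccc(C)c1)OC(=O)NCc1ccccc1` carries a methyl in place of hydrogen on an aromatic carbon; in this assay compound 3 again reaches only a limit, > 100000 nM. Because every value sits at the limit of > 100000 nM in this assay, at which 3 of the 3 values shown sit, the steps a step that the two limits leave unreadable from compound 1 to compound 2, a step that the two limits leave unreadable from compound 1 to compound 3 and a step that the two limits leave unreadable from compound 2 to compound 3 cannot be read in size. Compound 4 `CCC(COc1cc(Cl)ccc1Cl)OC(=O)NCc1ccccc1` differs from compound 3 by 2,5-dichlorophenyl in place of 3-methylphenyl on an oxygen on a saturated carbon. Among the measured compounds shown here, no measured step tells how this change acts; all three neighbours stand at the limit. Compound 4 is therefore expected to remain near that limit as well. The expected step is a number no higher from compound 3 to compound 4 (the limit leaves the size open), that is, nothing beyond the scatter. The estimate for compound 4 in this assay is 100000 nM, within a range from 30000 nM to 300000 nM.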

Compound 4, half-maximal inhibitory concentration: > 100000 nM
Compound 4: a limit, no number; the forecaster's own chance of this, stated with the estimate: 85%; the middle value lies on the limit itself.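

Compound 4 stands at a limit of the assay, as do compound 1, compound 2 and compound 3, so none of its steps to them can be read in size: the limit of > 100000 nM in this assay, at which 4 of the 4 values shown sit.

The compounds shown leave open how strongly any of the four inhibits the enzyme, and which change to the shared core, if any, would give a readable number.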